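This account rests on a few compounds, and the source may have more. Where it says the series, first, only, none or still open, it means among the compounds named here.

Compound 1 `COc1ccc(/C=C/C(=O)c2ccccc2-c2ccc(F)cc2)cc1OC` and compound 2 `COc1ccc(/C=C/C(=O)c2ccccc2-c2ccc(F)nc2)cc1OC` share one core, while compound 3 `COc1ccc(C(=O)/C=C/c2ccccc2-c2ccc(F)cc2)cc1O` and compound 4 `COc1ccc(C(=O)/C=C/c2ccccc2-c2ccc(F)nc2)cc1O` share another; how the two cores differ is not broken down here. In a functional assay on A549 cells (Homo sapiens) for antiproliferative activity, read by sulforhodamine B assay, with a stated time of 48 h (on this read-out higher numbers stand for weaker inhibition and lower numbers for stronger inhibition), compound 1 gives 440 nM and compound 2 gives 1200 nM. The change between them, (6-fluoropyridin-3-yl in place of 4-fluorophenyl on an aromatic carbon), made a 2.7-fold higher number from compound 1 to compound 2 (0.44 log units; beyond the scatter). In this assay compound 3 gives 940 nM, and compound 4 is not yet measured there. Compound 4 carries the same change on the core of compound 3, (6-fluoropyridin-3-yl in place of 4-fluorophenyl on an aromatic carbon). A step of similar size is expected from compound 3 to compound 4, roughly a 2.7-fold higher number from compound 3 to compound 4 (0.42 log units; beyond the scatter), because the single earlier case of this change gave a 2.7-fold higher number from compound 1 to compound 2 (0.44 log units; beyond the scatter); with only one such case, the expectation is loose. Compound 4 is therefore estimated at 2500 nM, likely between 1200 nM and 5500 nM.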

Compound 4, half-maximal inhibitory concentration: 3200 nM
The estimate for compound 4 lay 1.3-fold (0.11 log units) below the measured number; the measured number falls inside the stated range.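

Putting 6-fluoropyridin-3-yl in place of 4-fluorophenyl again weakened inhibition in this assay, with a 3.4-fold higher number from compound 3 to compound 4 (0.53 log units; beyond the scatter). On these two cores the change pushed the number the same way and by a comparable amount: the same change on two cores in this assay, a 2.7-fold higher number (0.44 log units; beyond the scatter) from compound 1 to compound 2 and a 3.4-fold higher number (0.53 log units; beyond the scatter) from compound 3 to compound 4, 1.2-fold (0.10 log units) apart, within the scatter of two such steps. Among these compounds, this shows that the step carried over from one core to the other here, but with only two cores in one cell assay, it neither explains why the number rises nor shows that the same would happen on a further core.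

The compounds shown leave open how other groups would behave at this place on either core, such as an unsubstituted phenyl, a pyridine ring without fluorine or a 4-methoxyphenyl.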